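The compounds below may be only part of what the source reports. "The series", "measured", "known", "first", "only" and "open" are said of these compounds alone.

In a functional assay on A549 cells (Homo sapiens) for inhibition, read by sulforhodamine B assay, with a stated time of 48 h (on this read-out lower numbers stand for higher toxicity in this test and higher numbers for lower toxicity in this test), compound 1 `COc1cc(-c2nn(-c3cccc(NC(=O)Nc4cc(C(F)(F)F)cc(C(F)(F)F)c4)c3)cc2-c2ccncc2)ccc1Cl` gives 18000 nM. Compound 2 `COc1cc(-c2nn(-c3cccc(NC(=O)c4cccc(C(F)(F)F)c4)c3)cc2-c2ccncc2)ccc1Cl` gives only a limit of the test, > 50000 nM. Compound 3 `COc1cc(-c2nn(-c3cccc(NC(=O)Nc4ccc(Cl)c(Cl)c4)c3)cc2-c2ccncc2)ccc1Cl` likewise stands only at a limit, > 50000 nM, so its place among the numbers shown is not fixed. The step that the two limits leave unreadable from compound 2 to compound 3 is therefore unreadable, and the limit of > 50000 nM in this assay, at which 2 of the 3 values shown sit, marks the limit where two of the three values sit. Compound 4 `COc1cc(-c2nn(-c3cccc(NC(=O)Nc4cccc(C(F)(F)F)c4)c3)cc2-c2ccncc2)ccc1Cl` differs from compound 3 by 3-(trifluoromethyl)phenyl in place of 3,4-dichlorophenyl on an amide-type nitrogen. No measured step covers this exchange; compound 1 and compound 2 together merely show that one value inside the range of this assay has appeared among these compounds. Compound 4 is therefore expected near 50000 nM, between 18000 nM and 150000 nM, an expected step of a number no higher from compound 3 to compound 4 (the limit leaves the size open) that most likely ends again at the limit.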

Compound 4, concentration lethal to 50% of the cells: > 50000 nM
Compound 4: a limit, no number (the forecaster's own chance of this, stated with the estimate: 70%); the middle value lies on the limit itself.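

For the compounds shown here, with hydrogen in place of trifluoromethyl on an aromatic carbon, this assay shows an at least 2.7-fold higher number from compound 1 to compound 4 (0.44 log units; beyond the scatter), so the second trifluoromethyl of compound 1 is the one change here tied to a readable difference. The value of compound 4 is a limit. The steps among compound 2, compound 3 and compound 4 cannot be read, since each joins two limits: the limit of > 50000 nM in this assay, at which 3 of the 4 values shown sit.

As far as these compounds go, what a nitrile or a tert-butyl group on that aromatic carbon would give remains open. So does the true position of compound 2, compound 3 and compound 4 beyond the limit.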